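What one methyl may do to compound 3

This account rests on a few compounds, and the source may have more. Where it says the series, first, only, none or still open, it means among the compounds named here.

Values measured in a functional assay on CCRF-CEM cells (Homo sapiens), with a stated time of 3 days (on this read-out lower numbers stand for stronger inhibition and higher numbers for weaker inhibition), are as follows
- Compound 1 `O=C(Nc1ccn([C@H]2OCC=CC2=O)c(=O)n1)c1ccccc1`: 46000 nM
- Compound 2 `C=C1C=CCO[C@@H]1n1ccc(NC(=O)c2ccccc2)nc1=O`: 432000 nM
- Compound 3 `C=C1[C@H](O)[C@H](O)CO[C@@H]1n1ccc(O)nc1=O`: > 800000 nM (a limit, not a number)

Compound 3 has no exact value and stands only at a limit, (the limit of > 800000 nM in this assay, at which 1 of the 3 values shown sits). Compound 4 `C=C1[C@H](O)[C@H](O)CO[C@@H]1n1cc(C)c(O)nc1=O` differs from compound 3 in one place, with methyl in place of hydrogen on an aromatic carbon and nothing else changed. Going by the values given here, the only measured step, a 9.4-fold higher number from compound 1 to compound 2 (0.97 log units; beyond the scatter), is a change on an aromatic nitrogen. Among the compounds with values here, it therefore bears on this methyl change only loosely, as a sense of scale, and no measured pair shows the same swap. Without such a pair, no step beyond the scatter is expected in this assay, and no direction is favoured. The expected step is a number no higher from compound 3 to compound 4 (the limit leaves the size open) and may not be resolved if compound 4 also reaches the limit. For compound 4 the estimate is 800000 nM, with an expected range from 300000 nM to 2000000 nM.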

Compound 4, half-maximal inhibitory concentration: >= 800000 nM
Compound 4: a limit, no number; the forecaster's own chance of this, stated with the estimate: 75%; the middle value sits exactly at the limit.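

In this assay compound 3 reads > 800000 nM as a limit and not a number. Going by these compounds alone, compound 4 reads >= 800000 nM as a limit too, so no step between compound 3 and compound 4 can be read. As far as these compounds go, whether methyl in place of hydrogen on an aromatic carbon changes inhibition at all, and in which direction, stays open.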